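This account rests on a few compounds, and the source may have more. Where it says the series, first, only, none or still open, it means among the compounds named here.

Of the compounds shown here, three built on a shared core have been tested in a functional assay on U-87MG ATCC cells for antiproliferative activity against U-87 MG (Homo sapiens), read by spectrophotometry, with a stated time of 2 days; a lower number here means a stronger inhibitor of growth, a higher number a weaker inhibitor of growth. Compound 1 `COc1cc(N2CCN(C(C)=O)CC2)ccc1Nc1ncc(C(F)(F)F)c(N2Cc3cccc(N(C)S(C)(=O)=O)c3C2)n1` gives 4700 nM, compound 2 `COc1cc(Nc2ncc(C(F)(F)F)c(N3Cc4cccc(N(C)S(C)(=O)=O)c4C3)n2)c(OC)cc1Cl` gives 6200 nM, and compound 3 `CN(c1cccc2c1CN(c1nc(Nc3cccc(Oc4ccccc4)c3)ncc1C(F)(F)F)C2)S(C)(=O)=O` gives 19500 nM. Compound 2 therefore lies within the usual scatter of compound 1, while compound 3 shows a number beyond the scatter from compound 2.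

The next compound to be tested is compound 4 `Cc1cc(C)cc(Nc2ncc(C(F)(F)F)c(N3Cc4cccc(N(C)S(C)(=O)=O)c4C3)n2)c1`, which differs from compound 2 in one place: 3,5-dimethylphenyl in place of 4-chloro-2,5-dimethoxyphenyl on a nitrogen on an aromatic ring. Put simply, 3,5-dimethylphenyl stands in place of 4-chloro-2,5-dimethoxyphenyl on a nitrogen on an aromatic ring.

Going by the values given here, no two measured compounds differ in only one place, so no direct step is available as a guide. The best available guide is the span of the measured values, from compound 1 at 4700 nM to compound 3 at 19500 nM. A slightly higher number is expected, but no change beyond the scatter. The estimated change is a 1.5-fold higher number from compound 2 to compound 4 (0.16 log units; within the scatter). The estimate for compound 4 is 9000 nM, with an expected range from 4000 nM to 20000 nM.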

Compound 4, concentration for 50% growth inhibition: > 30000 nM
Compound 4 ended at the assay's limit (the forecaster's own chance of this, stated with the estimate: 15%); middle value at least 3.3-fold (0.52 log units) away from the limit.
By their numbers in this assay, from the lowest: compounds 1 and 2 (each within the scatter of the next); then compound 3. At a limit, above all of these: compound 4.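

In this assay, going by these compounds alone, replacing 4-chloro-2,5-dimethoxyphenyl with 3,5-dimethylphenyl on this nitrogen gives an at least 4.8-fold higher number from compound 2 to compound 4 (0.68 log units; beyond the scatter), the first direct evidence that the group at this position affects growth inhibition. Compound 4 reaches > 30000 nM, which is a limit of the assay and not a number. The full size of the step therefore stays unknown: the limit of > 30000 nM in this assay, at which 1 of the 4 values shown sits.

The change removes the chlorine and the methoxy groups and also alters the pattern of substituents on the phenyl ring, so the compounds shown cannot tell which of these differences matters. On these data alone, it also remains open whether an amine or a carboxylic acid on this phenyl ring would bring the number down.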